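Methylsulfanyl for methoxy on a nucleoside analogue

The compounds below may be only part of what the source reports. "The series", "measured", "known", "first", "only" and "open" are said of these compounds alone.

Compound 2 `COc1ncnc2c1c(-c1cccs1)cn2[C@@H]1O[C@H](CO)[C@@H](O)[C@H]1O` gives 4850 nM in a functional assay on A549 cells (Homo sapiens), read by MTT assay, with a stated time of 72 h (on this read-out higher numbers stand for weaker inhibition and lower numbers for stronger inhibition), and stands lowest of the two numbers; its nearest neighbour, compound 1 `COc1ncnc2c1c(-c1ccsc1)cn2[C@@H]1O[C@H](CO)[C@@H](O)[C@H]1O`, gives 5170 nM, and the step of a 1.1-fold lower number from compound 1 to compound 2 (0.03 log units; within the scatter) lies within the scatter. Compound 3 `CSc1ncnc2c1c(-c1cccs1)cn2[C@@H]1O[C@H](CO)[C@@H](O)[C@H]1O` differs from compound 2 by methylsulfanyl in place of methoxy on an aromatic carbon. Within the data shown here, no measured step touches this place on the core, and the single step seen did not move the number beyond the scatter, so compound 3 is expected to show no step beyond the scatter, a 1.1-fold lower number from compound 2 to compound 3 (0.03 log units; within the scatter). Compound 3 is therefore estimated at 4500 nM, in the range 1500 nM to 14000 nM.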

Compound 3, half-maximal inhibitory concentration: > 20000 nM
Compound 3 was reported as a limit; the forecaster's own chance of this, stated with the estimate: 5%; middle value at least 4.4-fold (0.64 log units) away from the limit.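

Methylsulfanyl in place of methoxy gives an at least 4.1-fold higher number from compound 2 to compound 3 (0.61 log units; beyond the scatter) in this assay, so this place on the shared core responds to a change of oxygen to sulfur, whereas the earlier step between the two thiophenes stayed within the scatter. For compound 3 the value is a limit and not a number: the limit of > 20000 nM in this assay, at which 1 of the 3 values shown sits.

As far as these compounds go, whether an amine or a longer chain such as ethoxy at this place would keep the number near that of compound 2 stays open. So does whether the same change would act alike with the thiophen-3-yl group of compound 1.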